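Swapping an Acetamide Side Chain for a Furan Ring

The compounds below may be only part of what the source reports. "The series", "measured", "known", "first", "only" and "open" are said of these compounds alone.

Two compounds share one core and differ only in the group carried on a saturated chain carbon bound to a nitrogen on an aromatic ring. Compound 1 `CCOC(=O)CN(c1ccccc1)[C@H]1c2cc(C#N)ccc2OC(C)(C)[C@@H]1O` carries ethoxycarbonyl there, and compound 2 `CC(=O)NCCN(c1ccccc1)[C@H]1c2cc(C#N)ccc2OC(C)(C)[C@@H]1O` carries acetamidomethyl. In a functional assay (aorta) with Rattus norvegicus as the target (a higher number here means a weaker inhibitor, a lower number a stronger inhibitor), compound 1 gives only a limit, > 30000 nM. In this assay compound 2 likewise gives only a limit, > 30000 nM. The step that the two limits leave unreadable from compound 1 to compound 2 therefore cannot be read, because both values sit at the limit of > 30000 nM in this assay, at which 2 of the 2 values shown sit. Compound 2 thus stands where every value here stands: at the limit, with no number behind it.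

Compound 3 `CC1(C)Oc2ccc(C#N)cc2[C@H](N(Cc2ccco2)c2ccccc2)[C@H]1O` differs from compound 2 in one place: furan-2-yl in place of acetamidomethyl on a saturated chain carbon bound to a nitrogen on an aromatic ring. Going by the values given here, no measured step bears on this change, since the only step known has no readable size, and the acetamidomethyl group that leaves has never been paired with a number. The step of a number no higher from compound 2 to compound 3 (the limit leaves the size open) is accordingly expected to be none that the data can tell apart from the scatter, with a further limit the most likely outcome. Compound 3 is estimated at 30000 nM in this assay, within a range from 5000 nM to 100000 nM.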

Compound 3, half-maximal inhibitory concentration: 12000 nM
The estimate for compound 3 lay 2.5-fold (0.40 log units) above the measured number; low and high end bracket the measured number.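

The position is not closed to a measurable effect: with furan-2-yl on a saturated chain carbon bound to a nitrogen on an aromatic ring, this assay gives a number rather than a limit for the first time among these compounds. Replacing acetamidomethyl with furan-2-yl gives an at least 2.5-fold lower number from compound 2 to compound 3 (0.39 log units; beyond the scatter), and replacing ethoxycarbonyl with furan-2-yl gives an at least 2.5-fold lower number from compound 1 to compound 3 (0.39 log units; beyond the scatter), so the choice of group at this place can move the result beyond the usual scatter. Both steps give only the smallest possible change, not its true size, because the starting values for compounds 1 and 2 are limits: the limit of > 30000 nM in this assay, at which 2 of the 3 values shown sit.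

Acetamidomethyl and furan-2-yl differ in more than one feature, since the group that enters brings a five-membered aromatic ring and no hydrogen-bond donor, while the group that leaves has no ring and one hydrogen-bond donor, so these compounds cannot show which difference matters. Also open, as far as these compounds go, is whether phenyl, thiophen-2-yl or a saturated ring such as tetrahydrofuran-2-yl at the same place would give a lower number than compound 3 or a higher one.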